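Shortening the chain: from compound 2 to compound 3

The source may hold more compounds than are shown below. What is called first, only, known or untested is meant among the compounds shown, and "the series" means these compounds.

Values in a functional assay (trachea) with Cavia porcellus as the target; on this read-out higher numbers stand for weaker inhibition and lower numbers for stronger inhibition:
- compound 1 `CCCCn1nc(-c2cccnc2)c2ccccc2c1=O`: 2290 nM
- compound 2 `CCCCCCCCn1nc(-c2cccnc2)c2ccccc2c1=O`: 21900 nM

Compound 2 has the higher of the two numbers. Compound 3 `CC(C)=CCn1nc(-c2cccnc2)c2ccccc2c1=O` differs from it as follows: 2-methylprop-1-en-1-yl in place of heptyl on a saturated chain carbon bound to an aromatic nitrogen. For the measured compounds named here, the one measured step that bears on this is a 9.6-fold higher number from compound 1 to compound 2 (0.98 log units; beyond the scatter), which added butyl to the chain. Compound 3 loses heptyl and gains a smaller group, so a return towards compound 1 at 2290 nM is expected. The expected step in this assay is a 6.8-fold lower number from compound 2 to compound 3 (0.84 log units; beyond the scatter), towards a lower number and beyond the scatter. For compound 3 the estimated value is 3200 nM, with an expected range of 1100 nM to 9500 nM.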

Compound 3, half-maximal inhibitory concentration: 1380 nM
For compound 3 the middle estimate is 2.3-fold (0.37 log units) above the measured one; low and high end bracket the measured number.
By their numbers in this assay, from the lowest: compounds 3 and 1 (each within the scatter of the next); then compound 2.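

In this assay the change from octyl to 3-methylbut-2-en-1-yl gives a 16-fold lower number from compound 2 to compound 3 (1.20 log units; beyond the scatter) and recovers what the long chain lost. Against the shorter unbranched chain, the same group gives a 1.7-fold lower number from compound 1 to compound 3 (0.22 log units; within the scatter) and so offers no separation between the two, showing that a branched chain with a double bond is accepted on this saturated chain carbon bound to an aromatic nitrogen. Nothing available explains why these chains differ from octyl.

Still open, on these data alone, is how a chain shorter than butyl, such as ethyl, would read here. Also open, as far as these compounds go, is whether a benzyl group or a chain ending in an amine would fit at this position.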